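This account rests on a few compounds, and the source may have more. Where it says the series, first, only, none or still open, it means among the compounds named here.

Measured compounds:
Compound 1 `COc1nc(C)nc(/N=C/c2ccc(C)cc2)n1`: in an ADME assay on Vero cells (Chlorocebus sabaeus) for cytotoxicity, read by MTT assay, with a stated time of 72 h (a lower number here means a stronger inhibitor, a higher number a weaker inhibitor), compound 1 gives > 50 ug/mL, which is a limit of the assay and not a number.
Compound 2 `COc1nc(C)nc(/N=C/c2ccc(Br)cc2)n1`: in this assay compound 2 gives > 50 ug/mL, likewise a limit of the assay.

On the numbers shown, compound 2 therefore stands only at a limit, with no measured value below it. Within the data shown here, its single measured neighbour is compound 1, and the one step between them is a step that the two limits leave unreadable from compound 1 to compound 2, so the exchange of bromo for methyl tells nothing about size or direction. All that the measured material offers is the limit of > 50 ug/mL in this assay, at which 2 of the 2 values shown sit.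

Compound 3 `C=CCOc1ccc(/C=N/c2nc(C)nc(OC)n2)cc1` differs from compound 2 by allyloxy in place of bromo on an aromatic carbon. Among the measured compounds shown here, no measured step bears on this exchange, and the step from compound 1 to compound 2 is itself unreadable, so no size or direction can be carried over. Because the limit of > 50 ug/mL in this assay, at which 2 of the 2 values shown sit, describes both measured compounds, the most that can be expected is that compound 3 also fails to reach a readable value, with no step beyond the scatter. The step that the limit leaves unreadable from compound 2 to compound 3 is thus expected to be small or absent. Compound 3 is estimated at 80 ug/mL in this assay, within a range from 35 ug/mL to 200 ug/mL.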

Compound 3, half-maximal inhibitory concentration: > 50 ug/mL
Compound 3: no number, only a limit; the forecaster's own chance of this, stated with the estimate: 80%; the middle value lies beyond the limit too.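

Compound 3 gives > 50 ug/mL in this assay, which is a limit of the assay and not a number, so the steps to compound 3 from compound 1 and compound 2 cannot be read. The three compounds share only this: the limit of > 50 ug/mL in this assay, at which 3 of the 3 values shown sit.

The compounds shown leave open whether any of these exchanges on the aromatic carbon alters the value in this assay.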